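The compounds below may be only part of what the source reports. "The series", "measured", "known", "first", "only" and "open" are said of these compounds alone.

Measured in an in vitro functional assay on HEK285-7 cells for antagonist activity at prostaglandin D2 receptor 2 (Homo sapiens), read by BRET and beta-arrestin recruitment; on this read-out lower numbers stand for smaller maximal responses and higher numbers for larger maximal responses:
Compound 1 `O=C(O)Cc1sc(CS(=O)(=O)c2ccc(Cl)cc2)nc1-c1ccc(Cl)cc1` gives 30%.
Compound 2 `O=C(O)Cc1sc(C(c2ccc(F)cc2)c2ccc(F)cc2)nc1-c1ccnc(Cl)c1` gives 80%.
Compound 3 `O=C(O)Cc1sc(C(c2ccccc2)c2ccccc2)nc1-c1ccccc1` gives 80%.

Compound 2 stands level with compound 3 at the digits shown, the two together at the top of these three numbers; the gap between them lies within the scatter, so no order between compound 2 and compound 3 is claimed. Compound 1 sits well apart, clearly lower than compound 2, and that gap is beyond the scatter. Among the compounds with values here, no pair among the measured compounds differs in a single place, so no step is available to lean on.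

Within the data shown here, compound 4 `O=C(O)Cc1sc(C(c2ccc(F)cc2)c2ccc(F)cc2)nc1-c1ccnc(N2CCC2)c1` carries the single change azetidin-1-yl in place of chloro on an aromatic carbon relative to compound 2. Among the measured compounds shown here, the measured set gives no example of a change of this kind at this position, so the expectation rests only on compound 2 itself: a step from compound 2 to compound 4 in this assay is expected to stay within the scatter, at most a small drift downward. Compound 4 is therefore estimated at 75%, with a range from 55% to 95%, which means an expected step of a number 5 percentage points lower from compound 2 to compound 4 (within the scatter).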

Compound 4, largest response reached (reported as efficacy), in percent of the reference or control that the assay uses: 80%
The estimate for compound 4 lay 5 percentage points below the measured number; the measured number falls inside the stated range.
By their numbers in this assay, from the lowest: compound 1; then compounds 2, 3 and 4 (each within the scatter of the next).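

In this assay the series now has its first single-place step, which reads no change at the digits printed from compound 2 to compound 4 (within the scatter) for azetidin-1-yl in place of chloro. This position, on an aromatic carbon next to the ring nitrogen and meta to a large group, therefore accepts one four-membered non-aromatic ring with 1 hetero atom and a hydrogen-bond acceptor where a lone chlorine stood, with no shift in maximal response beyond the scatter. Nothing available explains why this exchange leaves the read-out where it is.

The compounds shown leave open how piperidin-1-yl, an open-chain dimethylamino or a carboxylic acid would read on this same carbon. They also leave open whether azetidin-1-yl in place of chloro reads the same way on a different core substitution, such as the sulfonylmethyl side chain of compound 1.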